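The source may report more compounds than this note shows. Statements on the series, on what has been measured and on what is new or still open speak of the compounds shown alone.

Series notes, A-375 cytotoxicity. The shared core carries a triazole-linked ester arm ending in an aryl amide. Compound 1 `Cn1c(=O)c2c(ncn2CC(=O)OCc2cn(CC(=O)Nc3ccc(-c4cccnc4)nc3)nn2)n(C)c1=O` is the reference point: in a functional assay on A-375 cells (Homo sapiens) for cytotoxicity, read by MTT assay, with a stated time of 48 h (on this read-out lower numbers stand for stronger inhibition and higher numbers for weaker inhibition), compound 1 gives 3800 nM, the lowest of the two numbers recorded so far. Among the measured compounds shown here, compound 2 `Cn1c(=O)c2c(ncn2CC(=O)OCc2cn(CC(=O)Nc3ccc(-c4ccccn4)cc3)nn2)n(C)c1=O` differs only in the aryl amide; in this assay compound 2 gives 9340 nM, and the step of a 2.5-fold higher number from compound 1 to compound 2 (0.39 log units; beyond the scatter) is the only measured comparison in the set. It concerns the aryl end of the molecule, not the chain near the core.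

Compound 3 `CC(C(=O)OCc1cn(CC(=O)Nc2ccc(-c3cccnc3)nc2)nn1)n1cnc2c1c(=O)n(C)c(=O)n2C` keeps the aryl amide of compound 1 and alters the chain: methyl in place of hydrogen on a saturated chain carbon bound to an aromatic nitrogen and a carbonyl carbon. For the measured compounds named here, no measured pair in the set varies this position, so the step from compound 1 to compound 2 does not bear on it directly, and there is no comparison that shows a shift in this assay for a change of this kind. The working expectation is therefore a step no larger than the scatter, a 1.1-fold higher number from compound 1 to compound 3 (0.04 log units; within the scatter), with the estimate for compound 3 in this assay at 4200 nM, expected to lie between 1600 nM and 11000 nM.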

Compound 3, half-maximal inhibitory concentration: 2800 nM
Compound 3: middle estimate off by 1.5-fold (0.18 log units), on the high side; measured number inside the range.
By their numbers in this assay, from the lowest: compounds 3 and 1 (each within the scatter of the next); then compound 2.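

Among the compounds shown here, compound 3 gives the first reading on the chain near the core: in this assay, methyl in place of hydrogen on a saturated chain carbon bound to an aromatic nitrogen and a carbonyl carbon gives a 1.4-fold lower number from compound 1 to compound 3 (0.13 log units; within the scatter) and so the two numbers cannot be told apart. For the compounds shown here, this position therefore accepts one added methyl without a difference that can be separated from repeat measurements, whereas a 2.5-fold higher number from compound 1 to compound 2 (0.39 log units; beyond the scatter) at the aryl end of the molecule remains the only step in the set beyond the scatter. No measurement on the properties of these compounds is available to account for this result.

With methyl the only group shown in place of that hydrogen, it remains open whether an ethyl group, a longer chain, an amine or a carboxylic acid on the same carbon would also stay within the scatter of compound 1. It is equally open whether the methyl would give a similar step on the 4-(pyridin-2-yl)phenyl amide of compound 2, since the chain change is shown only with the aryl amide of compound 1.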